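Replacing ethylsulfanyl with dimethylamino on a saturated chain carbon

A few compounds are considered here, and "the series" means these few. Any claim that something is new, unique, unknown or untested is made for them only; others in the source may bear on it.

Of the compounds shown here, two have so far been measured in a functional assay on THP-1 cells (Homo sapiens); a lower number here means a stronger inhibitor, a higher number a weaker inhibitor. Compound 1 (`CC[C@H]1c2c(cc(F)c(F)c2O)[C@H](Nc2cccc3[nH]c(=O)ccc23)[C@@](O)(C(F)(F)F)C1OC`) gives 6.31 nM, while compound 2 (`CCSC[C@@](O)([C@@H](Nc1cc(F)cc2[nH]c(=O)ccc12)c1ccc(OC)c(F)c1Cl)C(F)(F)F`) gives 1.59 nM. That is the lower of the two numbers, and the gap lies beyond the scatter, so compound 2 is the stronger inhibitor of the pair.

Compound 3 (`COc1ccc([C@H](Nc2cc(F)cc3[nH]c(=O)ccc23)[C@](O)(CN(C)C)C(F)(F)F)c(Cl)c1F`) keeps the rest of compound 2 but carries dimethylamino in place of ethylsulfanyl on a saturated chain carbon, two bonds along the chain from an oxygen on a saturated carbon. Among the measured compounds shown here, no measured pair shows this exchange, so the data offer no direct guide to its effect.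

For the measured compounds named here, with compound 2 at 1.59 nM holding the lowest number so far, a rise is expected to be more likely than a further fall in this assay, and a moderate one at that. The estimated change is a 3.1-fold higher number from compound 2 to compound 3 (0.50 log units; beyond the scatter), towards weaker inhibition. Compound 3 is expected to give 5 nM, with an estimated range from 1 nM to 25 nM.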

Compound 3, half-maximal inhibitory concentration in the THP-1 assay: 7.94 nM
The estimate for compound 3 lay 1.6-fold (0.20 log units) below the measured number; measured number inside the range.
By their numbers in the THP-1 assay, from the lowest: compound 2; then compounds 1 and 3 (each within the scatter of the next).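

Among the compounds shown here, the exchange of ethylsulfanyl for dimethylamino on a saturated chain carbon, two bonds along the chain from an oxygen on a saturated carbon, gives the first step that can be read at this position: in the THP-1 assay compound 2 gives 1.59 nM and compound 3 gives 7.94 nM, which is a 5.0-fold higher number from compound 2 to compound 3 (0.70 log units; beyond the scatter). The two groups match in their counts of heavy atoms and hydrogen-bond acceptors, so the position responds in this assay to a change that leaves those counts as they were. In a physicochemical assay for lipophilicity (a higher number here means a more lipophilic compound, a lower number a more polar compound), compound 2 gives 4.3 and compound 3 gives 4.4, which is a number 0.10 log units higher from compound 2 to compound 3 (within the scatter), so the partition coefficient does not separate the two compounds, and nothing measured here accounts for the step in the THP-1 assay.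

The compounds shown leave open how a primary amine, a morpholine ring or a longer thioether chain would fare on this carbon, and so whether the sulfur-bearing group is unusually well suited here or dimethylamino is unusually poorly suited. They also rest on this single pair, which leaves open whether the same exchange would give a similar step on a different core, such as that of compound 1.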